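Swapping the ring on the thiocarbonyl: thiomorpholine to piperidine

The compounds below may be only part of what the source reports. "The series", "measured", "known", "first", "only" and "open" are said of these compounds alone.

Measured compounds and their values:
compound 1 `Cc1ccnc(/C(N)=N/NC(=S)N2CCOCC2)c1`, 43.2%
compound 2 `Cc1ccnc(/C(N)=N/NC(=S)N2CCSCC2)c1`, 47.7%
compound 3 `N/C(=N\NC(=S)N1CCSCC1)c1ccccn1`, 34%

In a functional assay on A-375 cells (Homo sapiens) for cytotoxicity, read by MTT assay, with a stated time of 72 h, tested at 1 uM (on this read-out higher numbers stand for more inhibition of growth at the one concentration tested and lower numbers for less inhibition of growth), compound 2 gives the highest of the three numbers, although compound 1 sits within the scatter of it. The unmeasured compound 4 `Cc1ccnc(/C(N)=N/NC(=S)N2CCCCC2)c1` differs from compound 2 only by piperidin-1-yl in place of thiomorpholin-4-yl on a thiocarbonyl carbon. Among the measured compounds shown here, the only measured step that touches this same position is a number 4.5 percentage points higher from compound 1 to compound 2 (within the scatter), an exchange of one six-membered ring for another on the thiocarbonyl carbon that did not move the number beyond the scatter. Compound 2 is therefore expected to carry over largely unchanged, with a step of about a number 2.7 percentage points lower from compound 2 to compound 4 (within the scatter) expected. Compound 4 is estimated at 45%, with a range from 30% to 60%.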

Compound 4, percent growth inhibition at one concentration: 33.5%
Compound 4: middle estimate off by 11.5 percentage points, on the high side; the measured number falls inside the stated range.
By their numbers in this assay, from the lowest: compounds 4, 3, 1 and 2 (each within the scatter of the next, the first and the last beyond it).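

In this assay the exchange of thiomorpholin-4-yl for piperidin-1-yl gives a number 14.2 percentage points lower from compound 2 to compound 4 (beyond the scatter) and so shows that a ring swap on the thiocarbonyl carbon can shift the number clearly, which a number 4.5 percentage points higher from compound 1 to compound 2 (within the scatter) did not show. The exchange of morpholin-4-yl for piperidin-1-yl gives a number 9.7 percentage points lower from compound 1 to compound 4 (within the scatter) and leaves those two compounds unseparated. Still open, going by these compounds, is how an open-chain dimethylamino group or a piperazine ring would behave at this place. No supporting measurement explains these differences.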